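From vinylsulfonyl to vinylcarbonyl on the amine nitrogen

The source may report more compounds than this note shows. Statements on the series, on what has been measured and on what is new or still open speak of the compounds shown alone.

In a functional assay on MV4-11 cells (Homo sapiens) for antiproliferative activity, read by luminescence, with a stated time of 72 h (a lower number here means a stronger inhibitor, a higher number a weaker inhibitor), the measured compounds are these:
Compound 1 (`C=CS(=O)(=O)NC/C=C/c1cc(OC)cc(O)c1C(=O)OC(C)C`) gives 4660 nM
Compound 2 (`C=CS(=O)(=O)NC/C=C/c1cc(OC)cc(O)c1C(=O)OCc1ccc(Br)cc1`) gives 6060 nM
Compound 3 (`C=CS(=O)(=O)NC/C=C/c1cc(OC)cc(O)c1C(=O)OCc1ccc(F)cc1`) gives 5140 nM

Compound 1 stands within the scatter of both other compounds, so the three cannot be ranked. Compound 4 (`C=CC(=O)NC/C=C/c1cc(OC)cc(O)c1C(=O)OC(C)C`) differs from it at one place (vinylcarbonyl in place of vinylsulfonyl on an amine nitrogen). The measured steps (a 1.3-fold higher number from compound 1 to compound 2 (0.11 log units; within the scatter)) and (a 1.1-fold higher number from compound 1 to compound 3 (0.04 log units; within the scatter)) and (a 1.2-fold lower number from compound 2 to compound 3 (0.07 log units; within the scatter)) are all small, but none changes the group on the amine nitrogen, so the data hold no direct measure of this change. In this assay no step beyond the scatter is therefore expected, in either direction, though with wide uncertainty. The estimated step (a 1.1-fold higher number from compound 1 to compound 4 (0.03 log units; within the scatter)) is correspondingly small. For compound 4 the estimate is 5000 nM (expected range 1700 nM to 15000 nM).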

Compound 4, half-maximal inhibitory concentration: > 10000 nM
Compound 4 was reported as a limit (the forecaster's own chance of this, stated with the estimate: 10%); middle value at least 2.0-fold (0.30 log units) from the limit.
By their numbers in this assay, from the lowest: compounds 1, 3 and 2 (each within the scatter of the next). At a limit, above all of these: compound 4.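

Unlike the exchanges of isopropyl for 4-bromobenzyl or 4-fluorobenzyl, which all stayed within the scatter, the change on the amine nitrogen gives a step beyond it: an at least 2.1-fold higher number from compound 1 to compound 4 (0.33 log units; beyond the scatter) in this assay. With isopropyl in place, vinylcarbonyl therefore does not match vinylsulfonyl at this position. The full size of the step cannot be read because compound 4 is reported only as a limit: the limit of > 10000 nM in this assay, at which 1 of the 4 values shown sits.

From the compounds shown here alone, whether the same step holds with 4-bromobenzyl or 4-fluorobenzyl in place of isopropyl remains open. So does what an ethylsulfonyl or propionyl group on this nitrogen would give.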